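Extending the Methoxy of Compound 1 to Ethoxy

The source may report more compounds than this note shows. Statements on the series, on what has been measured and on what is new or still open speak of the compounds shown alone.

Compound 1 `COc1ccc(NC(=O)C(=O)c2cn(C(C)C)c3ccccc23)cn1` and compound 2 `COCC(C)n1cc(C(=O)C(=O)Nc2ccc(OC)nc2)c2ccccc21` are the two measured compounds. In a functional assay on FaDu cells (Homo sapiens) for cytotoxicity, read by MTT assay, with a stated time of 72 h (on this read-out lower numbers stand for higher toxicity in this test and higher numbers for lower toxicity in this test), compound 1 gives 85 nM, the highest of the two numbers; compound 2 gives 12 nM. Among the measured compounds shown here, the one measured step, a 7.1-fold lower number from compound 1 to compound 2 (0.85 log units; beyond the scatter), concerns a change on a saturated chain carbon two bonds along the chain from an aromatic nitrogen, a different place from the change examined here. Compound 3 `CCOc1ccc(NC(=O)C(=O)c2cn(C(C)C)c3ccccc23)cn1` differs from compound 1 by methyl in place of hydrogen on a saturated chain carbon bound to an oxygen on an aromatic ring. For the measured compounds named here, no measured step bears directly on this change; the data hold no pair that differs at the oxygen on the aromatic ring. The change is therefore expected to stay within the scatter, with no clear direction, and no change at the digits printed from compound 1 to compound 3 (within the scatter) is the expected step. For compound 3 the estimate in this assay is 85 nM, within a range from 30 nM to 240 nM.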

Compound 3, concentration lethal to 50% of the cells: 175 nM
Beside the measured number, compound 3's estimate is 2.1-fold (0.31 log units) below it; low and high end bracket the measured number.
By their numbers in this assay, from the lowest: compound 2; then compound 1; then compound 3.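

In this assay, among the compounds shown here, the change from methoxy to ethoxy gives a 2.1-fold higher number from compound 1 to compound 3 (0.31 log units; beyond the scatter) and so shows that this position, which no earlier pair touched, responds to a change: a single added methyl on the saturated chain carbon bound to an oxygen on an aromatic ring moves the number beyond the scatter, towards lower toxicity in this test. For the compounds shown here, the step is modest, and it runs in the opposite direction to the one earlier step, a 7.1-fold lower number from compound 1 to compound 2 (0.85 log units; beyond the scatter), which lies at a different place. The data offer nothing that explains this shift.

On these data alone, whether a longer chain such as propoxy would carry the number further in the same direction remains open, as does the effect of an amine in place of the methoxy group. Also open, as far as these compounds go, is whether ethoxy would shift the number in the same way when paired with the side chain of compound 2.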